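From 2-Fluorophenyl to 4-Methylphenyl on a Ring Nitrogen

The compounds below may be only part of what the source reports. "The series", "measured", "known", "first", "only" and "open" are said of these compounds alone.

In a functional assay on A549 cells (Homo sapiens) for inhibition, read by sulforhodamine B assay (a lower number here means a stronger inhibitor, a higher number a weaker inhibitor), compound 1 (`COC(=O)CC/C(C)=C/Cc1c(OC)c(C)c2c(c1OCC#CCN1CCN(c3ccccc3F)CC1)C(=O)OC2`) gives 45300 nM and stands level with compound 2 (`COC(=O)CC/C(C)=C/Cc1c(OC)c(C)c2c(c1OCC#CCN1CCC(Cc3ccccc3)CC1)C(=O)OC2`) at 40700 nM within the scatter. Compound 3 (`COC(=O)CC/C(C)=C/Cc1c(OC)c(C)c2c(c1OCC#CCN1CCN(c3ccc(C)cc3)CC1)C(=O)OC2`) differs from compound 1 by one change (4-methylphenyl in place of 2-fluorophenyl on an amine nitrogen in a ring): 4-methylphenyl in place of 2-fluorophenyl on an amine nitrogen in a ring. Among the measured compounds shown here, no measured pair shows such a change, so no step beyond the scatter is expected in this assay in either direction. The estimated move (a 1.2-fold lower number from compound 1 to compound 3 (0.08 log units; within the scatter)) stays small. Compound 3 is expected at 38000 nM with an estimated range from 17000 nM to 75000 nM in this read-out.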

Compound 3, half-maximal inhibitory concentration: > 50000 nM
Compound 3: a limit, no number; the forecaster's own chance of this, stated with the estimate: 20%; middle value at least 1.3-fold (0.11 log units) from the limit.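

In this assay compound 3 gives > 50000 nM and this is a limit of the assay, not a number. Putting 4-methylphenyl in place of 2-fluorophenyl on this amine nitrogen in a ring gives an at least 1.1-fold higher number from compound 1 to compound 3 (0.04 log units; that floor lies within the scatter) and so brings no gain. The full size of the step cannot be read because it rests on a limit: the limit of > 50000 nM in this assay, at which 1 of the 3 values shown sits.

The compounds shown leave open whether an amine or a carboxylic acid on this phenyl ring, or a longer chain carrying that ring on the nitrogen, would give a lower number.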